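Side-chain variation on the shared core: toward compound 4

This account rests on a few compounds, and the source may have more. Where it says the series, first, only, none or still open, it means among the compounds named here.

Compound 1 `COC(=O)Cn1c(=O)c(C)cn([C@@H]2O[C@H](CO[Si](C)(C)C(C)(C)C)[C@@]3(OS(=O)(=O)C=C3N)[C@H]2O[Si](C)(C)C(C)(C)C)c1=O`: in a functional assay on CCRF-CEM cells (Homo sapiens) (a higher number here means that more compound is tolerated, a lower number that less compound is tolerated), compound 1 gives > 152000 nM, a limit of the assay rather than a number.
Compound 2 `Cc1cn([C@@H]2O[C@H](CO[Si](C)(C)C(C)(C)C)[C@@]3(OS(=O)(=O)C=C3N)[C@H]2O[Si](C)(C)C(C)(C)C)c(=O)n(CC(N)=O)c1=O`: in this assay compound 2 gives 13300 nM.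
Compound 3 `Cc1cn([C@@H]2O[C@H](CO[Si](C)(C)C(C)(C)C)[C@@]3(OS(=O)(=O)C=C3N)[C@H]2O[Si](C)(C)C(C)(C)C)c(=O)n(CC2CC2)c1=O`: in this assay compound 3 gives 60400 nM.

Compound 3 stands at the highest of the two numbers; compound 2 sits nearest, with a 4.5-fold higher number from compound 2 to compound 3 (0.66 log units; beyond the scatter), and the remaining value is a limit. Compound 4 `Cc1cn([C@@H]2O[C@H](CO[Si](C)(C)C(C)(C)C)[C@@]3(OS(=O)(=O)C=C3N)[C@H]2O[Si](C)(C)C(C)(C)C)c(=O)n(CCO)c1=O` differs from compound 3 in one place: hydroxymethyl in place of cyclopropyl on a saturated chain carbon bound to an aromatic nitrogen. The measured steps at this place are a 4.5-fold higher number from compound 2 to compound 3 (0.66 log units; beyond the scatter) and an at least 2.5-fold lower number from compound 1 to compound 3 (0.40 log units; beyond the scatter); in both, a group bearing a carbonyl gave way to cyclopropyl and the number rose. Removing cyclopropyl again, as here, is expected to move the number back toward that of compound 2, which carries carbamoyl on the same saturated chain carbon and gives 13300 nM. Compound 4 is therefore expected to give 25000 nM, within 8000 nM to 80000 nM. The expected step is a 2.4-fold lower number from compound 3 to compound 4 (0.38 log units; beyond the scatter), modest and downward.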

Compound 4, half-maximal cytotoxic concentration: 11300 nM
Estimate against measurement, compound 4: 2.2-fold (0.34 log units) above; the range from low to high includes it.
By their numbers in this assay, from the lowest: compounds 4 and 2 (each within the scatter of the next); then compound 3. At a limit, above all of these: compound 1.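

In this assay, hydroxymethyl and carbamoyl on this saturated chain carbon cannot be told apart, with a 1.2-fold lower number from compound 2 to compound 4 (0.07 log units; within the scatter). Set against cyclopropyl, the same change gives a 5.3-fold lower number from compound 3 to compound 4 (0.73 log units; beyond the scatter), so the rise seen with cyclopropyl is undone by a group other than carbamoyl, and compound 3 stands apart from both compound 2 and compound 4. Compound 1 gives > 152000 nM, a limit of the assay and not a number, and an at least 13-fold lower number from compound 1 to compound 4 (1.12 log units; beyond the scatter) rests on that limit, so methoxycarbonyl goes against any reading in which cyclopropyl gives the highest number: the limit of > 152000 nM in this assay, at which 1 of the 4 values shown sits.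

Going by these compounds, whether the number follows the end group or the length of the chain remains open. An amine, a carboxylic acid or a longer chain ending in hydroxyl on the same saturated chain carbon would separate these readings.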